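Swapping a hydroxyphenyl isomer on a weak inhibitor

A few compounds are considered here, and "the series" means these few. Any claim that something is new, unique, unknown or untested is made for them only; others in the source may bear on it.

Measured so far:
compound 1 `Oc1cccc(-c2cc(-c3ccccc3C(F)(F)F)cc(-c3cccc(O)c3)n2)c1`: 15200 nM
compound 2 `Oc1cccc(-c2cc(-c3ccccc3OC(F)(F)F)cc(-c3ccccc3O)n2)c1`: 15200 nM

In a functional assay on HeLa cells (Homo sapiens) for inhibition (a lower number here means a stronger inhibitor, a higher number a weaker inhibitor), compound 1 gives 15200 nM. Compound 2 stands level with it, giving 15200 nM in this assay, a difference within the scatter. Compound 3 `Oc1cccc(-c2cc(-c3ccccc3OC(F)(F)F)cc(-c3cccc(O)c3)n2)c1` is the next step: 3-hydroxyphenyl in place of 2-hydroxyphenyl on an aromatic carbon. For the measured compounds named here, no measured pair shows what this change alone does, and both measured compounds are weak inhibitors of similar strength. The step of a 1.0-fold lower number from compound 2 to compound 3 (0.01 log units; within the scatter) is therefore expected to be small, with no clear direction beyond the scatter. Compound 3 is estimated at 15000 nM in this assay, likely between 6000 nM and 40000 nM.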

Compound 3, half-maximal inhibitory concentration: 16700 nM
Beside the measured number, compound 3's estimate is 1.1-fold (0.05 log units) below it, and the stated range covers the measured number.
By their numbers in this assay, from the lowest: compounds 1, 2 and 3 (each within the scatter of the next).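

Putting 3-hydroxyphenyl in place of 2-hydroxyphenyl gives a 1.1-fold higher number from compound 2 to compound 3 (0.04 log units; within the scatter) in this assay, so this first direct pair shows that the swap makes no clear difference on this weak inhibitor. Trifluoromethoxy in place of trifluoromethyl gives a 1.1-fold higher number from compound 1 to compound 3 (0.04 log units; within the scatter), so that one-place change also stays within the scatter. Nothing else measured here offers an explanation for these results.

Still open, going by these compounds, is whether any other group at this place could shift the number beyond the scatter. An amine or a carboxylic acid on the phenyl ring in place of the hydroxyl would test this.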